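A Sulfamoylphenyl Swap in an Inactive Triazole Series

The source may report more compounds than this note shows. Statements on the series, on what has been measured and on what is new or still open speak of the compounds shown alone.

Compound 3 has the structure `CCOc1ccccc1-n1nncc1CN1C(=O)C2(C(C#N)=C(N)Oc3c2c2nc4ccccc4nc2c2ccccc32)c2ccccc21`. In a functional assay on HCT-116 cells (Homo sapiens) for antiproliferative activity, read by MTT assay, with a stated time of 48 h (a higher number here means a weaker inhibitor, a lower number a stronger inhibitor), compound 3 gives > 50000 nM, which is a limit of the assay rather than a number. Two companions share its core. Compound 1, `N#CC1=C(N)Oc2c(c3nc4ccccc4nc3c3ccccc23)C12C(=O)N(Cc1cnnn1-c1ccc(Cl)cc1)c1ccccc12`, carries a 4-chlorophenyl on the aromatic nitrogen; in this assay compound 1 gives > 50000 nM, also a limit. Compound 2, `N#CC1=C(N)Oc2c(c3nc4ccccc4nc3c3ccccc23)C12C(=O)N(Cc1cnnn1-c1ccccc1Cl)c1ccccc12`, carries a 2-chlorophenyl on that nitrogen; in this assay compound 2 gives > 50000 nM, again a limit. The steps between them are therefore unreadable: a step that the two limits leave unreadable from compound 1 to compound 2, a step that the two limits leave unreadable from compound 1 to compound 3 and a step that the two limits leave unreadable from compound 2 to compound 3. All three values sit at the same point, as the limit of > 50000 nM in this assay, at which 3 of the 3 values shown sit, shows.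

Compound 4, `N#CC1=C(N)Oc2c(c3nc4ccccc4nc3c3ccccc23)C12C(=O)N(Cc1cnnn1-c1cccc(S(N)(=O)=O)c1)c1ccccc12`, differs from compound 3 by 3-sulfamoylphenyl in place of 2-ethoxyphenyl on an aromatic nitrogen. Going by the values given here, nothing measured so far separates one aryl group from another; every variant stays at the limit. Compound 4 is therefore expected to stay at the limit as well, estimated near 60000 nM with a range from 30000 nM to 150000 nM. The step this estimate means, a step that the limit leaves unreadable from compound 3 to compound 4, is expected to be no change the assay can read.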

Compound 4, half-maximal inhibitory concentration: 11300 nM
The estimate for compound 4 lay 5.3-fold (0.73 log units) above the measured number, and the stated range ends above it.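

The aryl group on the aromatic nitrogen can move the number after all: in this assay, 3-sulfamoylphenyl gives an at least 4.4-fold lower number from compound 3 to compound 4 (0.64 log units; beyond the scatter), an at least 4.4-fold lower number from compound 2 to compound 4 (0.64 log units; beyond the scatter) and an at least 4.4-fold lower number from compound 1 to compound 4 (0.64 log units; beyond the scatter). Each of these steps is only a minimum, and the steps among compound 1, compound 2 and compound 3 still cannot be read. Compound 4 is the only compound shown that has a measured number rather than a limit, so the earlier silence of this position belonged to those three aryl groups and not to the position itself: the limit of > 50000 nM in this assay, at which 3 of the 4 values shown sit.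

The compounds shown do not tell whether the sulfamoyl group is specifically needed, or whether a carboxylic acid or an amine on the same phenyl ring would also lower the number. They also leave open how much further the number could fall with other groups at this position.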